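The compounds below may be only part of what the source reports. "The series", "measured", "known", "first", "only" and "open" are said of these compounds alone.

Among the compounds with values here, in an ADME assay on HFF cells (Homo sapiens) for cytotoxicity, with a stated time of 8 days (on this read-out higher numbers stand for lower toxicity in this test and lower numbers for higher toxicity in this test), the shared core of compound 2 `CCCCCOc1nc(N)nc2c1ncn2/C=C1/CC1(CO)CO` gives 259000 nM, and this is the only true number among the three values measured. The other two sit at a limit of the assay (the limit of > 300000 nM in this assay, at which 2 of the 3 values shown sit). Compound 1 `CC(C)CSc1nc(N)nc2c1ncn2/C=C1/CC1(CO)CO` gives > 300000 nM, which is a limit rather than a number. Compound 3 `Nc1nc(N2CCCC2)c2ncn(/C=C3/CC3(CO)CO)c2n1` likewise gives > 300000 nM, again a limit of the assay. The new compound 4 `Nc1nc(OCc2ccccc2)c2ncn(/C=C3/CC3(CO)CO)c2n1` differs from compound 2 by one change, (phenyl in place of butyl on a saturated chain carbon bound to an oxygen on an aromatic ring). The measured steps that touch compound 2 alter the group on the aromatic carbon, not the chain itself: an at least 1.1-fold lower number from compound 1 to compound 2 (0.06 log units; that floor lies within the scatter) and an at least 1.1-fold higher number from compound 2 to compound 3 (0.06 log units; that floor lies within the scatter), neither readable beyond the usual scatter. Within the data shown here, no measured pair shows what swapping butyl for phenyl on the chain does. Compound 4 is therefore expected to stay near compound 2, with an estimated 259000 nM (between 120000 nM and 500000 nM). That expectation amounts to an estimated step of no change at the digits printed from compound 2 to compound 4 (within the scatter).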

Compound 4, half-maximal cytotoxic concentration: > 300000 nM
Compound 4: a limit, no number; the forecaster's own chance of this, stated with the estimate: 40%; middle value at least 1.1-fold (0.06 log units) away from the limit.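

In this assay, phenyl in place of butyl on a saturated chain carbon bound to an oxygen on an aromatic ring gives an at least 1.1-fold higher number from compound 2 to compound 4 (0.06 log units; that floor lies within the scatter). Within the data shown here, this is the first look at a change within the chain rather than a swap of the whole group on the aromatic carbon, and the aromatic ring brings no sign of higher toxicity in this test. The reading of compound 4 is a limit and not a number, so the steps linking it to compound 1 and compound 3 cannot be read, because these three compounds all sit at the same limit: the limit of > 300000 nM in this assay, at which 3 of the 4 values shown sit.

Going by these compounds, how far compound 1, compound 3 and compound 4 truly differ remains open. So does how an amine, a carboxylic acid or a longer chain at this place would read.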